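Changing the acyl ring of compound 1

This account rests on a few compounds, and the source may have more. Where it says the series, first, only, none or still open, it means among the compounds named here.

Compound 1, `CN(C(=O)NC(=O)c1ccccc1F)c1nc(C(F)(F)F)c(C(=O)N/N=C/c2ccc(C(F)(F)F)cc2)s1`, gives 3.97 ug/mL in a functional assay on HeLa cells (Homo sapiens) for inhibition, read by MTT assay, with a stated time of 72 h; on this read-out lower numbers stand for stronger inhibition and higher numbers for weaker inhibition.
Compound 2, `CN(C(=O)NC(=O)c1ccccc1F)c1nc(C(F)(F)F)c(C(=O)N/N=C/c2cccc(C(F)(F)F)c2)s1`, gives 19.1 ug/mL in this assay.

Compound 1 has the lowest number of the two, and the step of a 4.8-fold higher number from compound 1 to compound 2 (0.68 log units; beyond the scatter) is the only measured one. Compound 3, `CN(C(=O)NC(=O)c1cccc(C(F)(F)F)c1)c1nc(C(F)(F)F)c(C(=O)N/N=C/c2ccc(C(F)(F)F)cc2)s1`, differs from compound 1 by 3-(trifluoromethyl)phenyl in place of 2-fluorophenyl on a carbonyl carbon. Going by the values given here, no measured step touches this position; the step from compound 1 to compound 2 concerns another part of the molecule and so gives no guide here. Compound 3 is therefore expected to stay near compound 1, with an estimated step of a 1.3-fold higher number from compound 1 to compound 3 (0.10 log units; within the scatter). The estimate for compound 3 in this assay is 5 ug/mL, within 1.5 ug/mL to 16 ug/mL.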

Compound 3, half-maximal inhibitory concentration: 7.35 ug/mL
For compound 3 the middle estimate is 1.5-fold (0.17 log units) below the measured one; the measured number falls inside the stated range.
By their numbers in this assay, from the lowest: compounds 1 and 3 (each within the scatter of the next); then compound 2.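

In this assay, 3-(trifluoromethyl)phenyl in place of 2-fluorophenyl on the carbonyl carbon gives a 1.9-fold higher number from compound 1 to compound 3 (0.27 log units; within the scatter). This one swap therefore brings in a larger group, with 10 heavy atoms instead of 7, and the two numbers stay within the usual scatter of each other. No available evidence explains this result. Still open, on these data alone, is whether this carbonyl carbon would accept something other than a substituted phenyl ring, such as an amine or a carboxylic acid, and whether a simple unsubstituted phenyl ring would read the same.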